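The source may hold more compounds than are shown below. What is called first, only, known or untested is meant among the compounds shown, and "the series" means these compounds.

Working notes on the series. For the measured compounds named here, in a functional assay on A549 cells (Homo sapiens) for antiproliferative activity, read by MTT assay, with a stated time of 72 h (a higher number here means a weaker inhibitor, a lower number a stronger inhibitor), compound 2 (`NC1=NC2(CCOCC2)N(OCCCOc2ccccc2Cl)C(N)=N1`) gives 2700 nM and holds the higher of the two numbers so far, while compound 1 (`COc1ccc(OCCCON2C(N)=NC(N)=NC23CCOCC3)cc1`) gives 660 nM as the lower one. Going by the values given here, the only measured step is a 4.1-fold higher number from compound 1 to compound 2 (0.61 log units; beyond the scatter) for 2-chlorophenyl in place of 4-methoxyphenyl on an oxygen on a saturated carbon. It is modest but beyond the scatter.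

Compound 3 (`Cc1cc(C)cc(OCCCON2C(N)=NC(N)=NC23CCOCC3)c1`) has 3,5-dimethylphenyl in place of 2-chlorophenyl at that same place (3,5-dimethylphenyl in place of 2-chlorophenyl on an oxygen on a saturated carbon). Among the compounds with values here, no measured compound carries 3,5-dimethylphenyl, so the single step is only an indirect guide. It shows that a change at this place can move the number by a modest amount. Compound 2 at 2700 nM sits at the high end of the pair, so a fall is expected rather than a rise, though with little confidence.

The expected change is a 2.3-fold lower number from compound 2 to compound 3 (0.35 log units; beyond the scatter) and this estimate is somewhat smaller than the measured step. For compound 3 the estimate is 1200 nM in this assay with 400 nM to 3500 nM as the expected range.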

Compound 3, half-maximal inhibitory concentration: 710 nM
Compound 3: the middle estimate sits 1.7-fold (0.23 log units) above what was measured; low and high end bracket the measured number.
By their numbers in this assay, from the lowest: compounds 1 and 3 (each within the scatter of the next); then compound 2.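

In this assay, 3,5-dimethylphenyl in place of 2-chlorophenyl on the oxygen gives a 3.8-fold lower number from compound 2 to compound 3 (0.58 log units; beyond the scatter), a modest step that runs opposite in direction to the earlier step, so changes at this place have now moved the number both ways. Against 4-methoxyphenyl, the same group gives a 1.1-fold higher number from compound 1 to compound 3 (0.03 log units; within the scatter), which places compound 1 and compound 3 level, although the two compounds carry different groups on their phenyl rings. Of the three compounds, only compound 2, with its 2-chlorophenyl group, stands apart from the others, and no data in hand bear on the reason for this.

Whether the higher number of compound 2 goes with the chlorine itself or with where it sits on the phenyl ring remains an open question. Also open, from the compounds shown here alone, is how the number would respond to a phenyl ring bearing an amine or a carboxylic acid, or to a longer chain in place of the present saturated chain.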